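Series notes: fluoro substitution from compound 1 to compound 3

The compounds below may be only part of what the source reports. "The series", "measured", "known", "first", "only" and "open" are said of these compounds alone.

Measured so far:
compound 1, `O=C(Nc1nc2ccccc2s1)c1cn(-c2ccccc2)nc1-c1ccccc1`, 10400 nM
compound 2, `Cc1ccc2nc(NC(=O)c3cn(-c4ccccc4)nc3-c3ccccc3)sc2c1`, 15700 nM

In a functional assay on PC-3 cells (Homo sapiens) for cytotoxicity, read by MTT assay, with a stated time of 72 h (on this read-out higher numbers stand for weaker inhibition and lower numbers for stronger inhibition), compound 1 gives 10400 nM, and compound 2 lies within the scatter of it, as a 1.5-fold higher number from compound 1 to compound 2 (0.18 log units; within the scatter) shows. Compound 3, `O=C(Nc1nc2ccccc2s1)c1cn(-c2ccccc2)nc1-c1ccc(F)cc1`, differs from compound 1 by fluoro in place of hydrogen on an aromatic carbon. Among the compounds with values here, no measured step touches this change; the single step available, a 1.5-fold higher number from compound 1 to compound 2 (0.18 log units; within the scatter), concerns a different substitution and stays within the scatter. With nothing to argue for a shift, the step from compound 1 to compound 3 is expected to be a 1.1-fold lower number from compound 1 to compound 3 (0.04 log units; within the scatter), that is none beyond the scatter. Compound 3 is accordingly estimated at 9500 nM, with a range of 3500 nM to 26000 nM.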

Compound 3, half-maximal inhibitory concentration: 7130 nM
Compound 3: the middle estimate sits 1.3-fold (0.12 log units) above what was measured; measured number inside the range.
By their numbers in this assay, from the lowest: compounds 3, 1 and 2 (each within the scatter of the next, the first and the last beyond it).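

Within the data shown here, replacing phenyl with 4-fluorophenyl is the first change at this aryl group, para to a large group, and in this assay it gives a 1.5-fold lower number from compound 1 to compound 3 (0.16 log units; within the scatter). This position therefore accepts a single fluoro with no shift beyond the scatter, as the methyl step elsewhere on the core did. No experimental evidence here bears on the reason for this result.

As far as these compounds go, whether a methoxy group, an amine or a carboxylic acid at this place would move the number beyond the scatter remains open. So does the outcome of combining the fluoro and methyl changes on the core of compound 1.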